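The source may report more compounds than this note shows. Statements on the series, on what has been measured and on what is new or still open speak of the compounds shown alone.

Two compounds of the series have so far been run in a functional assay on the whole organism for inhibition, with Rattus norvegicus as the target, at a dose of 1 mg/kg by the oral route; a higher number here means more inhibition at the dose given (going by the name of the read-out), a lower number less inhibition. Compound 1 `CNc1cccc(NC(=O)C(=O)O)c1C#N` gives 96% in this assay. Compound 2 `CCNc1cccc(NC(=O)C(=O)O)c1C#N` gives 58.9%. Going by the values given here, the one step between them, a number 37.1 percentage points lower from compound 1 to compound 2 (beyond the scatter), is the only measured step in the set. On these numbers compound 2 stands lowest of the two, with compound 1 its nearest neighbour and higher by a margin beyond the scatter.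

Compound 3 `Cc1cccc(NC(=O)C(=O)O)c1C#N` is the next point. Relative to compound 2 the change is methyl in place of ethylamino on an aromatic carbon. The measured step bears on this only loosely: it concerned the saturated chain on the nitrogen, whereas here the whole ethylamino group goes and a methyl takes its place on the ring carbon. What that step does show is that the read-out at this position is sensitive to the substituent, and that the larger group gave the lower number. The entering methyl counts fewer heavy atoms than the leaving ethylamino, but the donor and acceptor counted in that group are lost, and nothing measured tells how that weighs. The expected step of a number 8.9 percentage points lower from compound 2 to compound 3 (within the scatter) is therefore uncertain in direction and the range is kept wide. Compound 3 is estimated at 50%, between 15% and 85%.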

Compound 3, a percentage reported as inhibition, in the whole organism at one dose (the size of the read-out at that dose, not a potency): 32.3%
The estimate for compound 3 lay 17.7 percentage points above the measured number; measured number inside the range.
By their numbers in this assay, from the lowest: compound 3; then compound 2; then compound 1.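

At this aromatic carbon, ortho to a cyano group, the nitrogen-linked groups can now be set against a plain methyl in this assay: the change from ethylamino to methyl gives a number 26.6 percentage points lower from compound 2 to compound 3 (beyond the scatter), and the change from methylamino to methyl gives a number 63.7 percentage points lower from compound 1 to compound 3 (beyond the scatter). The earlier step alone could be read as a larger group giving a lower number, but compound 3 goes against that reading, since it carries the smallest of the three groups and has the lowest number, so the order of the three does not follow group size. The change to methyl removes heavy atoms and also the donor and acceptor counted in ethylamino, these losses cannot be separated on the three compounds, and no measurement at hand accounts for the differences.

Still open, going by these compounds, is how an unsubstituted amine, a dimethylamino group, a propylamino chain or a methoxy group on this carbon would compare with compound 1. A single oral dose also leaves open how the three compounds would compare at other doses, as each number is the size of the read-out at that dose and not a potency.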